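From 1-benzothiophen-3-yl to 4-fluorophenyl on a Shared Core

The compounds below may be only part of what the source reports. "The series", "measured", "known", "first", "only" and "open" are said of these compounds alone.

Compound 1 `Cc1cc(Nc2cc(-c3ccccc3)[nH]n2)n2nc(SCc3csc4ccccc34)nc2n1`: 29200 nM
Compound 2 `Cc1cc(Nc2cc(-c3ccc(Cl)cc3)[nH]n2)n2nc(SCc3ccc(Br)cc3)nc2n1`: 28200 nM

Of the compounds shown here, two on the same core have been tested so far in an ADME assay on GES1 cells (Homo sapiens) for inhibition, read by MTT assay, with a stated time of 72 h; on this read-out lower numbers stand for stronger inhibition and higher numbers for weaker inhibition. Compound 1 gives 29200 nM, and compound 2 gives 28200 nM. Compound 1 holds the higher of these two numbers, but the gap to compound 2 is tiny and lies within the usual scatter of this assay, so the two results are best read as the same. The next compound, compound 3 `Cc1cc(Nc2cc(-c3ccccc3)[nH]n2)n2nc(SCc3ccc(F)cc3)nc2n1`, keeps the core of compound 1 and changes only the group on the saturated chain carbon bound to a sulfur: 4-fluorophenyl in place of 1-benzothiophen-3-yl on a saturated chain carbon bound to a sulfur. Within the data shown here, no measured pair shows what such a change does here, and the two numbers in hand sit close together despite different substituents. The step from compound 1 to compound 3 is therefore expected to be small, with no clear direction beyond the scatter, as a 1.0-fold higher number from compound 1 to compound 3 (0.01 log units; within the scatter) states. Compound 3 is expected to give about 30000 nM, within a range from 12000 nM to 75000 nM.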

Compound 3, half-maximal inhibitory concentration: 35500 nM
Compound 3: middle estimate off by 1.2-fold (0.07 log units), on the low side; measured number inside the range.
By their numbers in this assay, from the lowest: compounds 2, 1 and 3 (each within the scatter of the next).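

In this assay, among these compounds, putting 4-fluorophenyl in place of 1-benzothiophen-3-yl on a saturated chain carbon bound to a sulfur gives a 1.2-fold higher number from compound 1 to compound 3 (0.08 log units; within the scatter) and provides the first comparison on the shared core in which only one place differs. The position can therefore go from a group of two aromatic rings with 9 heavy atoms, including a sulfur, to a group of one aromatic ring with 7 heavy atoms, including a fluorine, without a step beyond the scatter. Nothing measured on these compounds explains the result.

As far as these compounds go, all of this rests on one pair with two aromatic groups, so it remains open whether a group of another kind at this position, such as an amine, a carboxylic acid or a longer chain, would leave the number as it is or move it beyond the scatter. Compound 2 differs from compound 1 and compound 3 in more than one place, so it cannot show whether the same swap would give a similar step alongside a 4-chlorophenyl group on the core.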